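The source may hold more compounds than are shown below. What is called first, only, known or untested is meant among the compounds shown, and "the series" means these compounds.

Compound 3 `COc1ccc(CN(C(=O)CSc2nc3ccccc3s2)c2cc(OC)c(OC)c(OC)c2)cc1N` stands second highest of the three numbers in a functional assay on MGC-803 cells (Homo sapiens) for antiproliferative activity, read by MTT assay, with a stated time of 48 h (a higher number here means a weaker inhibitor, a lower number a stronger inhibitor), where compound 3 gives 84 nM. Compound 1 `COc1ccc2nc(SCC(=O)N(Cc3ccc(OC)c(O)c3)c3cc(OC)c(OC)c(OC)c3)sc2c1` gives 71 nM in this assay, a gap within the scatter, whereas compound 2 `COc1cc(N(Cc2ccc(C)cc2)C(=O)CSc2nc3ccccc3s2)cc(OC)c1OC` gives 54200 nM. Compound 4 `COc1ccc(CN(C(=O)CSc2nc3ccccc3s2)c2cc(OC)c(OC)c(OC)c2)cc1OC` differs from compound 3 by methoxy in place of amino on an aromatic carbon. Within the data shown here, the only measured step touching this benzyl group is a 650-fold lower number from compound 2 to compound 3 (2.81 log units; beyond the scatter), which shows that the substituents on it matter strongly. Compound 1 carries a hydroxy group where compound 4 carries methoxy, and its number lies close to that of compound 3. For compound 4 the step is therefore expected to be small, a 1.8-fold higher number from compound 3 to compound 4 (0.25 log units; within the scatter). Compound 4 is estimated at 150 nM, within a range from 50 nM to 600 nM.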

Compound 4, half-maximal inhibitory concentration: 34100 nM
Estimate against measurement, compound 4: 230-fold (2.36 log units) below, outside the stated range (above it).
By their numbers in this assay, from the lowest: compounds 1 and 3 (each within the scatter of the next); then compounds 4 and 2 (each within the scatter of the next).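

In this assay, methoxy in place of amino on this aromatic carbon is far from a minor swap: a 410-fold higher number from compound 3 to compound 4 (2.61 log units; beyond the scatter) ties the low number of compound 3 to the amino group, at least among the groups compared here. The 3,4-dimethoxybenzyl group gives no clear advantage over 4-methylbenzyl, with a 1.6-fold lower number from compound 2 to compound 4 (0.20 log units; within the scatter). Nothing measured here explains this loss. On these data alone, it remains open whether the low number would persist with a methylamino or an acetamido group at this place.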